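The source may hold more compounds than are shown below. What is called first, only, known or untested is meant among the compounds shown, and "the series" means these compounds.

Two compounds open the account. Compound 1 `COc1ccc2c(c1)CC(C(=O)Nc1ccc(-c3cn[nH]c3)c(OC)c1)CO2` and compound 2 `COc1cc(-c2cn[nH]c2)ccc1NC(=O)C1COc2ccc(F)cc2C1` share one core and differ only in the substituent on the fused aromatic ring. In an assay on cells for inhibition of Rho-associated protein kinase 2 (Homo sapiens) (on this read-out higher numbers stand for weaker inhibition and lower numbers for stronger inhibition), compound 1 reaches only the limit of the assay, < 6 nM, not a number. In this assay compound 2 likewise reaches only the limit, < 6 nM, and so stands at a boundary rather than at a value. What the data hold on this point is the limit of < 6 nM in this assay, at which 2 of the 2 values shown sit. Compound 3 `COc1cc(-c2cn[nH]c2)ccc1NC(=O)C1COc2ccc(Cl)cc2C1` follows from compound 2 by a single change, chloro in place of fluoro on an aromatic carbon, on a six-membered aromatic ring of carbon only that is part of a fused system of two rings. Among the compounds with values here, no measured pair shows this exchange, so the expected step is a step that the limit leaves unreadable from compound 2 to compound 3, within the scatter and in no fixed direction. Compound 3 is thus expected to give about 4 nM in this assay, in a range from 1 nM to 12 nM, most probably once more as a limit only.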

Compound 3, half-maximal inhibitory concentration: 66 nM
The estimate for compound 3 lay 17-fold (1.22 log units) below the measured number; the measured number lies above the stated range.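

In this assay, this aromatic carbon of the fused system proves sensitive to the exchange of one halogen for another: chloro in place of fluoro gives an at least 11-fold higher number from compound 2 to compound 3 (1.04 log units; beyond the scatter). Within the data shown here, compound 3 is also the first compound here to give a number rather than a limit, so the account now has a value clear of the boundary of the assay. The true size of the step cannot be read, only its lower bound, because compound 2 gives a limit and not a number: the limit of < 6 nM in this assay, at which 2 of the 3 values shown sit.

What the compounds shown leave open is how this same carbon would read with bromo, a methyl group or a nitrile, and so whether the step is particular to chloro. They also do not show what lies behind the step, as nothing measured here speaks to its cause.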